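A few compounds are considered here, and "the series" means these few. Any claim that something is new, unique, unknown or untested is made for them only; others in the source may bear on it.

Measured so far: compound 1 `CC(C)CCNC(=O)C(C)NC(=O)CCC(=O)[C@H](CC(C)C)NC(=O)C(NC(=O)CC(C)C)C(C)C` gives 2140 nM in an assay on isolated protein for inhibition of Pepsin A (Sus scrofa) (a higher number here means a weaker inhibitor, a lower number a stronger inhibitor), and compound 2 `CC(C)CCNC(=O)C(C)NC(=O)[C@H](Cc1ccccc1)C[C@H](O)[C@H](CC(C)C)NC(=O)C(NC(=O)CC(C)C)C(C)C` gives 140 nM in this assay.

Compound 1 stands at the higher of these two numbers, so it is the weaker inhibitor of the pair. Compound 2 sits well below it, and the gap between the two is beyond the usual scatter. Compound 2 differs from compound 1 in more than one place along the chain, so no single change can be credited with that gap.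

Compound 3 `CC(C)CCNC(=O)C(C)NC(=O)C(CC(=O)[C@H](CC(C)C)NC(=O)C(NC(=O)CC(C)C)C(C)C)Cc1ccccc1` takes one of those changes alone: benzyl in place of hydrogen on a saturated chain carbon bound to a carbonyl carbon and a saturated chain carbon. Compound 2 also carries this benzyl group, but together with a different chain, so the two structures give only a hint of what the benzyl alone does. Because compound 2 gives 140 nM with the benzyl present, the step from compound 1 to compound 3 is expected to lower the number, beyond the scatter yet smaller than the whole distance to compound 2, an expected step of a 5.4-fold lower number from compound 1 to compound 3 (0.73 log units; beyond the scatter). Compound 3 is therefore estimated at 400 nM in this assay, within a range of 120 nM to 1300 nM.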

Compound 3, inhibition constant: 72 nM
Compound 3: the middle estimate sits 5.6-fold (0.74 log units) above what was measured, outside the stated range (below it).
By their numbers in this assay, from the lowest: compounds 3 and 2 (each within the scatter of the next); then compound 1.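

In this assay, putting benzyl in place of hydrogen on a saturated chain carbon bound to a carbonyl carbon and a saturated chain carbon gives a 30-fold lower number from compound 1 to compound 3 (1.47 log units; beyond the scatter), a large step from this one change alone. Until now the benzyl group could be seen only alongside other differences in the chain, so its own contribution could not be separated from theirs; here the rest of the structure stays the same, and the step belongs to this single replacement of a hydrogen atom by 7 heavy atoms that include one six-membered aromatic ring. The data at hand offer no independent measurement that would explain why this replacement has such an effect.

With benzyl as the only group shown at this place, it remains open whether the aromatic ring is what counts or whether a plain carbon group, such as a methyl or a longer alkyl chain, would produce a similar step. The compounds shown also leave open how the number would respond to an amine or a carboxylic acid on the same carbon.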